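The source may report more compounds than this note shows. Statements on the series, on what has been measured and on what is new or still open speak of the compounds shown alone.

In a functional assay on DMS-114 cells (Homo sapiens) for inhibition (on this read-out lower numbers stand for stronger inhibition and higher numbers for weaker inhibition), compound 1 (`N[C@H]1CC[C@H](Nc2nc(NCc3cccc(I)c3)c3ncn(C4CCCC4)c3n2)CC1`) gives 1000 nM and compound 2 (`N[C@H]1CC[C@H](Nc2nc(NCC3CC3)c3ncn(C4CCCC4)c3n2)CC1`) gives 1400 nM on the same core. The step between them (a 1.4-fold higher number from compound 1 to compound 2 (0.15 log units; within the scatter)) lies within the scatter, so compound 2 stands level with compound 1 on these numbers. Compound 3 (`C[C@H](Nc1nc(N[C@H]2CC[C@H](N)CC2)nc2c1ncn2C1CCCC1)c1ccccc1`) differs from compound 2 in one group (1-phenylethyl in place of cyclopropylmethyl on a nitrogen on an aromatic ring): 1-phenylethyl in place of cyclopropylmethyl on a nitrogen on an aromatic ring. For the measured compounds named here, only one measured step bears on this change. It concerns the same substituent, with cyclopropyl in place of 3-iodophenyl on a saturated chain carbon bound to a nitrogen on an aromatic ring. Exchanging that aromatic ring for a cyclopropyl ring moved the number only within the scatter (a 1.4-fold higher number from compound 1 to compound 2 (0.15 log units; within the scatter)). Going by the values given here, no measured compound carries a defined stereocentre in this group, so the support is thin. No step beyond the scatter is therefore expected in this assay, and neither direction is favoured. The expected step (a 1.4-fold lower number from compound 2 to compound 3 (0.15 log units; within the scatter)) is an estimate that stays within the scatter. Compound 3 is estimated at 1000 nM (expected range 400 nM to 2500 nM).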

Compound 3, half-maximal inhibitory concentration: 6600 nM
Estimate against measurement, compound 3: 6.6-fold (0.82 log units) below, outside the stated range (above it).
By their numbers in this assay, from the lowest: compounds 1 and 2 (each within the scatter of the next); then compound 3.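

In this assay, the substituent on the nitrogen on the aromatic ring does matter: 1-phenylethyl in place of cyclopropylmethyl gives a 4.7-fold higher number from compound 2 to compound 3 (0.67 log units; beyond the scatter), and 1-phenylethyl in place of 3-iodobenzyl gives a 6.6-fold higher number from compound 1 to compound 3 (0.82 log units; beyond the scatter). An aromatic ring in this group does not by itself go with the weaker inhibition, since compound 1 also carries one and stands level with compound 2, as a 1.4-fold higher number from compound 1 to compound 2 (0.15 log units; within the scatter) shows; among these three compounds, only the 1-phenylethyl group, with its defined stereocentre, is set apart. Nothing in the data at hand accounts for this loss of inhibition.

On these data alone, what remains open is whether the opposite configuration of the 1-phenylethyl group, or a plain benzyl group, would stand with compound 3 or with compounds 1 and 2, so the extra methyl and the stereocentre cannot be separated from the loss of the iodine. As far as these compounds go, it is also open how this assay would read with an amine or a carboxylic acid on the benzyl ring, or with a longer chain in place of the cyclopropylmethyl group.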